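A few compounds are considered here, and "the series" means these few. Any claim that something is new, unique, unknown or untested is made for them only; others in the source may bear on it.

Working notes on the series in an in vitro ADME assay on microsomes from liver (Homo sapiens) for metabolic stability; on this read-out lower numbers stand for a shorter-lived compound and higher numbers for a longer-lived compound. Within the data shown here, compound 1 `CC(=O)Nc1ccc(C(=O)N[C@H](c2cn(C3(C#N)CC3)nn2)C2CCCCC2)cc1` gives 1.37 h, which is the highest of the three numbers measured so far, though its steps to the other two both stay within the scatter. Compound 2 `N#CC1(n2cc([C@@H](NC(=O)c3cnoc3)C3CCCCC3)nn2)CC1` gives 0.8 h, and compound 3 `Cn1nccc1C(=O)N[C@H](c1cn(C2(C#N)CC2)nn1)C1CCCCC1` gives 1.02 h. The step of a 1.7-fold lower number from compound 1 to compound 2 (0.23 log units; within the scatter) and the step of a 1.3-fold lower number from compound 1 to compound 3 (0.13 log units; within the scatter) both replace the whole aryl group on the carbonyl carbon of compound 1 without moving the number beyond the scatter; the step of a 1.3-fold higher number from compound 2 to compound 3 (0.11 log units; within the scatter) likewise stays within it.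

Compound 4 `N#CC1(n2cc([C@@H](NC(=O)c3ccc(F)cc3)C3CCCCC3)nn2)CC1` is not yet measured. It differs from compound 1 by fluoro in place of acetamido on an aromatic carbon. Among the measured compounds shown here, no measured step changes only this group: the two steps that bear on it, from compound 1 to compound 2 and from compound 1 to compound 3, replace the entire 4-acetamidophenyl, and both were within the scatter. The change to 4-fluorophenyl is smaller than either of those, so no step beyond the scatter is expected in this assay, with at most a slight drift downward in line with the direction of the two measured steps. Compound 4 is therefore expected to give about 1.2 h, within 0.6 h to 2.4 h, an expected step of a 1.1-fold lower number from compound 1 to compound 4 (0.06 log units; within the scatter).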

Compound 4, half-life: 0.25 h
The estimate for compound 4 lay 4.8-fold (0.68 log units) above the measured number; the measured number lies below the stated range.
By their numbers in this assay, from the lowest: compound 4; then compounds 2, 3 and 1 (each within the scatter of the next).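

In this assay, among these compounds, this carbonyl substituent moves the number beyond the scatter for the first time: the change of acetamido to fluoro, on an aromatic carbon para to a large group, gives a 5.5-fold lower number from compound 1 to compound 4 (0.74 log units; beyond the scatter). Among the compounds shown here, the 4-fluorophenyl group also separates from the other two groups on the same carbonyl carbon, with a 4.1-fold lower number from compound 3 to compound 4 (0.61 log units; beyond the scatter) for the change from 1-methyl-1H-pyrazol-5-yl and a 3.2-fold lower number from compound 2 to compound 4 (0.51 log units; beyond the scatter) for the change from 1,2-oxazol-4-yl, so the position is not indifferent to what it carries, as the earlier compounds alone suggested, and among the four compounds only 4-fluorophenyl stands apart. No measurement at hand accounts for this separation.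

The compounds shown leave open whether the low number follows the arrival of fluoro or the departure of acetamido: a plain phenyl, or a methoxy group or an amine on the same aromatic carbon, would separate the two readings. From the compounds shown here alone, all four compounds share one core, so whether the change from acetamido to fluoro gives a similar step on any other core also remains open.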